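The source may hold more compounds than are shown below. What is called first, only, known or untested is meant among the compounds shown, and "the series" means these compounds.

Three compounds share one core and differ only in the aryl group on the amine nitrogen. Compound 1 `O=C(/C=C\Nc1ccc2cc[nH]c2c1)c1nc(-c2ccc(C(F)(F)F)cc2)n2ccccc12` carries a 1H-indol-6-yl group there; in a functional assay on HCT-116 cells (Homo sapiens) for cytotoxicity, read by MTT assay, with a stated time of 48 h (a lower number here means a stronger inhibitor, a higher number a weaker inhibitor), compound 1 gives only a limit, > 30000 nM, and the limit of > 30000 nM in this assay, at which 1 of the 3 values shown sits, marks that ceiling. Compound 2 `O=C(/C=C\Nc1ccc2[nH]ccc2c1)c1nc(-c2ccc(C(F)(F)F)cc2)n2ccccc12` carries 1H-indol-5-yl and gives 27100 nM. Compound 3 `O=C(/C=C\Nc1ccc(Cl)cc1)c1nc(-c2ccc(C(F)(F)F)cc2)n2ccccc12` carries 4-chlorophenyl and gives 11500 nM, the lowest of the two numbers shown; the nearest value is that of compound 2, and the step of a 2.4-fold lower number from compound 2 to compound 3 (0.37 log units; beyond the scatter) lies beyond the scatter, as does an at least 2.6-fold lower number from compound 1 to compound 3 (0.41 log units; beyond the scatter). The step of an at least 1.1-fold lower number from compound 1 to compound 2 (0.04 log units; that floor lies within the scatter) is within the scatter.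

Compound 4 `COc1ccc(N/C=C\C(=O)c2nc(-c3ccc(C(F)(F)F)cc3)n3ccccc23)cc1` differs from compound 3 by methoxy in place of chloro on an aromatic carbon. Among the measured compounds shown here, no measured step exchanges one substituent for another on the same phenyl ring; the measured steps only swap whole aryl groups. The author therefore expects for compound 4 a step of a 1.4-fold higher number from compound 3 to compound 4 (0.14 log units; within the scatter), with no strong direction, and estimates 16000 nM in this assay, within a range of 6000 nM to 40000 nM.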

Compound 4, half-maximal inhibitory concentration: 7720 nM
For compound 4 the middle estimate is 2.1-fold (0.32 log units) above the measured one, and the stated range covers the measured number.
By their numbers in this assay, from the lowest: compounds 4 and 3 (each within the scatter of the next); then compound 2. At a limit, above all of these: compound 1.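

In this assay, among the compounds shown here, methoxy in place of chloro, para to a large group, is the first change here of one substituent alone rather than a whole aryl group, and a 1.5-fold lower number from compound 3 to compound 4 (0.17 log units; within the scatter) leaves the two groups indistinguishable. The 4-methoxyphenyl group also stays clear of both indolyl compounds, with a 3.5-fold lower number from compound 2 to compound 4 (0.55 log units; beyond the scatter) and with an at least 3.8-fold lower number from compound 1 to compound 4 (0.58 log units; beyond the scatter). The second of these steps is only a floor, since compound 1 gives a limit and not a number: the limit of > 30000 nM in this assay, at which 1 of the 4 values shown sits.

With only chloro and methoxy shown in this place, it remains open whether an amine, a carboxylic acid or a longer alkoxy chain there would move the number beyond the scatter. On these data alone, it is also open whether the 4-methoxyphenyl group would hold its place if the trifluoromethyl on the other phenyl ring were replaced by a nitrile.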